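The compounds below may be only part of what the source reports. "The series", "measured", "known", "first", "only" and "open" are said of these compounds alone.

Working notes on the series. Compound 3 `CC1=C(C(=O)OC(C)(C)C)C(c2cccs2)NC(=O)N1` shares its core with compound 1 `CC1=C(C(=O)Nc2ccc(Br)cc2)C(c2ccccc2)NC(=O)N1` and compound 2 `CC1=C(C(=O)Nc2ccccc2Cl)C(c2ccc([N+](=O)[O-])cc2)NC(=O)N1`, and all three have been run for tolerability. In an ADME assay on Vero cells (Chlorocebus sabaeus) for cytotoxicity, read by XTT assay, with a stated time of 72 h (a lower number here means that less compound is tolerated, a higher number that more compound is tolerated), compound 3 gives only a limit, namely > 100000 nM. In this assay compound 1 likewise gives only a limit, > 100000 nM. Compound 2 is recorded in this assay as "non-toxic" (no number reported), with no number attached. Compound 3 therefore stands where the rest of the set stands, at the ceiling of the measurement, which is what the limit of > 100000 nM in this assay, at which 2 of the 3 values shown sit, describes. Among the compounds with values here, no step between two measured compounds is available, so the change to compound 4 `CC1=C(C(=O)Nc2cccnc2)C(c2cccs2)NC(=O)N1` cannot be scaled from a measured pair. The change itself is (pyridin-3-yl)amino in place of tert-butoxy on a carbonyl carbon. Since the limit of > 100000 nM in this assay, at which 2 of the 3 values shown sit, holds for compound 1 and compound 3, and compound 2 shows no number at all, no step beyond the scatter is expected in this assay. The expected step that the limit leaves unreadable from compound 3 to compound 4 is none beyond the scatter. Compound 4 is therefore estimated at 150000 nM, within 40000 nM to 500000 nM, with a further limit rather than a number the likelier outcome.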

Compound 4, half-maximal cytotoxic concentration: > 100000 nM
Compound 4 ended at the assay's limit (the forecaster's own chance of this, stated with the estimate: 75%); the middle value is on the limit's open side.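

Within the data shown here, compound 4, like compound 3, gives only a limit in this assay, so no step between compound 3 and compound 4 can be read. The compounds shown leave open whether any change on the shared core would give a readable number in this assay.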